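The source may report more compounds than this note shows. Statements on the series, on what has been measured and on what is new or still open speak of the compounds shown alone.

Three compounds have been measured in a functional assay on the whole organism (artery, strain albino) with Rattus norvegicus as the target, with a stated time of 15 min, at a dose of 10 mg/kg by the oral route; on this read-out lower numbers stand for less inhibition and higher numbers for more inhibition at the one dose given (going by the name of the read-out):

compound 1, `COc1ccc(C2N=C(SCc3cccc(Cl)c3)NC(C)=C2C(=O)Nc2ccc(F)cc2)cc1OC`, 2.1%
compound 2, `COc1ccc(C2N=C(SCc3ccc(Cl)cc3)NC(C)=C2C(=O)Nc2ccc(F)cc2)cc1OC`, 3.1%
compound 3, `COc1ccc(C2N=C(SCc3cccc(Cl)c3)NC(C)=C2C(=O)Nc2ccc(Br)cc2)cc1`, 3.1%

Compound 1 and compound 2 share a core and differ in one place, (4-chlorophenyl in place of 3-chlorophenyl on a saturated chain carbon bound to a sulfur). The step that this made in this assay is a number 1 percentage points higher from compound 1 to compound 2 (within the scatter). Compound 3 carries the same side chain as compound 1 on a different core; how the two cores differ is not broken down here. In this assay compound 3 gives the same number as compound 2, and its value sits close to that of compound 1 as well, so all three measured values lie within the usual scatter of one another.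

Compound 4, `COc1ccc(C2N=C(SCc3ccc(Cl)cc3)NC(C)=C2C(=O)Nc2ccc(Br)cc2)cc1`, has not yet been measured. It differs from compound 3 by 4-chlorophenyl in place of 3-chlorophenyl on a saturated chain carbon bound to a sulfur, the same change that separates compound 1 from compound 2; it occurs twice among these four compounds. Because the earlier step of a number 1 percentage points higher from compound 1 to compound 2 (within the scatter) was small, the step from compound 3 to compound 4 is expected to be small too, about a number 0.9 percentage points higher from compound 3 to compound 4 (within the scatter). In this assay compound 4 is therefore estimated at 4%, expected to fall between 0% and 12%.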

Compound 4, a percentage reported as inhibition, in the whole organism at one dose (the size of the read-out at that dose, not a potency): 3.1%
Estimate against measurement, compound 4: 0.9 percentage points above; the range from low to high includes it.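

Putting 4-chlorophenyl in place of 3-chlorophenyl on a saturated chain carbon bound to a sulfur gives no change at the digits printed from compound 3 to compound 4 (within the scatter) in this assay. Set beside the earlier case, the change gives the same picture on both cores: the same change on two cores in this assay, a number 1 percentage points higher (within the scatter) from compound 1 to compound 2 and no change at the digits printed (within the scatter) from compound 3 to compound 4, 1 percentage points apart, within the scatter of two such steps. On these data alone, this shows that, on these two cores, the change carries over without any step that stands out from the scatter, but it does not show that the change has a real effect on either core, and any small effect or small difference between the cores would stay hidden, while other cores remain untested by these data.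

The compounds shown leave open what a clearly different group would do on that chain carbon, such as a carboxylic acid or an amine in place of the chlorophenyl ring, or a longer chain in place of the chlorobenzyl. They also leave open whether any compound of this kind would stand apart from these closely grouped values at the one dose given.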